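This account rests on a few compounds, and the source may have more. Where it says the series, first, only, none or still open, it means among the compounds named here.

Compound 1 `COc1ccc(CNc2nc([SeH])nc3ccccc23)cc1` gives > 100000 nM in a functional assay on HT-29 cells (Homo sapiens) for cytotoxicity, read by MTT assay, with a stated time of 72 h; on this read-out higher numbers stand for lower toxicity in this test and lower numbers for higher toxicity in this test; this is a limit of the assay, not a number.
Compound 2 `[SeH]c1nc([SeH])c2ccccc2n1` gives 87900 nM in this assay.
Compound 3 `COc1ccc(CNc2nc(SC)nc3ccccc23)cc1` gives > 100000 nM in this assay; this too is a limit, not a number.

Compound 1 thus stands only at a limit, namely (the limit of > 100000 nM in this assay, at which 2 of the 3 values shown sit). Compound 4 `CSc1ccc(CNc2nc([SeH])nc3ccccc23)cc1` differs from compound 1 by methylsulfanyl in place of methoxy on an aromatic carbon. Within the data shown here, the only step measured in a single place, a step that the two limits leave unreadable from compound 1 to compound 3, concerns a different part of the shared core and cannot be read, so nothing measured here speaks to the change toward compound 4, in either direction. Compound 4 is therefore expected to stay close to compound 1, with a step of a number no higher from compound 1 to compound 4 (the limit leaves the size open). Compound 4 is estimated at 100000 nM, within a range from 40000 nM to 250000 nM, and most likely again reported only as a limit.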

Compound 4, concentration lethal to 50% of the cells: > 100000 nM
Compound 4: only a limit was reported (the forecaster's own chance of this, stated with the estimate: 65%); the middle value sits exactly at the limit.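

Among these compounds, compound 1 and compound 4 are both reported only as a limit, not a number, so no step between them can be read: the limit of > 100000 nM in this assay, at which 3 of the 4 values shown sit. From the compounds shown here alone, whether methylsulfanyl in place of methoxy changes the result in this assay at all stays open.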